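The source may report more compounds than this note shows. Statements on the series, on what has been measured and on what is new or still open speak of the compounds shown alone.

Of the compounds shown here, three sharing one core have been tested in an assay on HEK293 cells for binding affinity to 5-hydroxytryptamine receptor 7 (Homo sapiens), read by radioligand binding, tested at 1 uM; on this read-out higher numbers stand for more inhibition at the one concentration tested (going by the name of the read-out) and lower numbers for less inhibition. Compound 1 `CN1CCCN(CCn2ccc3ccc(F)cc32)CC1` gives 60%. Compound 2 `CN1CCCN(CCn2ccc3ccc(N)cc32)CC1` gives 0%, and compound 3 `CN1CCCN(CCn2ccc3ccc(O)cc32)CC1` gives 28%. Compound 3 therefore stands second highest of the three: the step of a number 32 percentage points lower from compound 1 to compound 3 (beyond the scatter) places it well under compound 1, while the step of a number 28 percentage points higher from compound 2 to compound 3 (beyond the scatter) places it above compound 2. Compound 4 `CN1CCCN(CCn2ccc3ccc(C(N)=O)cc32)CC1` has not yet been measured; compared with compound 3 it differs in this way: carbamoyl in place of hydroxy on an aromatic carbon. For the measured compounds named here, no measured step involves carbamoyl, so the only guide is that exchanging the group on that aromatic carbon has moved this assay a great deal, both in a number 32 percentage points lower from compound 1 to compound 3 (beyond the scatter) and in a number 28 percentage points higher from compound 2 to compound 3 (beyond the scatter). A shift beyond the scatter in either direction is plausible, and none can be ruled out. Compound 4 is estimated to give 25%, within the range 0% to 55%. That estimate means an expected step of a number 3 percentage points lower from compound 3 to compound 4 (within the scatter), close to no change, reflecting the absence of any direct guide for this exchange.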

Compound 4, a percentage reported as inhibition, at one concentration (the size of the read-out at that concentration, not a potency): 33%
Beside the measured number, compound 4's estimate is 8 percentage points below it; low and high end bracket the measured number.
By their numbers in this assay, from the lowest: compound 2; then compounds 3 and 4 (each within the scatter of the next); then compound 1.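

In this assay, carbamoyl in place of hydroxy on this aromatic carbon gives a number 5 percentage points higher from compound 3 to compound 4 (within the scatter), so in this pair a group of 3 heavy atoms reads the same, within the scatter, as a group of 1 heavy atom. The other two exchanges place carbamoyl in the middle of the series: carbamoyl in place of amino gives a number 33 percentage points higher from compound 2 to compound 4 (beyond the scatter), and carbamoyl in place of fluoro gives a number 27 percentage points lower from compound 1 to compound 4 (beyond the scatter). No measurement at hand explains why these groups fall where they do.

Still open, as far as these compounds go, is whether another halogen such as chloro would match or pass fluoro at this place. A nitrile or a carboxylic acid there might equally stay level with hydroxy and carbamoyl or move away from them.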